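The source may report more compounds than this note shows. Statements on the series, on what has been measured and on what is new or still open speak of the compounds shown alone.

Of the compounds shown here, two of a shared core have been measured in an ADME assay on TZM cells (Homo sapiens) for cytotoxicity, read by CCK-8 assay, with a stated time of 2 days; on this read-out lower numbers stand for higher toxicity in this test and higher numbers for lower toxicity in this test. Compound 1 `CC(=O)Oc1ccc(/C=C/S(=O)(=O)CCc2ccc(NC(=O)c3ccccc3)cc2)cc1OC(C)=O` gives 108000 nM in this assay. Compound 2 `COc1ccc(C(=O)Nc2ccc(CCS(=O)(=O)/C=C/c3ccc(OC(C)=O)c(OC(C)=O)c3)cc2)cc1` gives 858000 nM in this assay, the higher of the two numbers, and so the less toxic of the pair on this read-out. Among the measured compounds shown here, the one step between them, methoxy in place of hydrogen on an aromatic carbon, gave a 7.9-fold higher number from compound 1 to compound 2 (0.90 log units; beyond the scatter).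

Compound 3 `CC(=O)Oc1ccc(/C=C/S(=O)(=O)CCc2ccc(NC(=O)c3ccc(F)cc3)cc2)cc1OC(C)=O` has not yet been measured in this assay. It differs from compound 2 in one place: fluoro in place of methoxy on an aromatic carbon. For the measured compounds named here, no measured step shows fluoro in place of methoxy, nor fluoro in place of hydrogen, on this aromatic carbon; the only guide is that the same position carried hydrogen in compound 1 and methoxy in compound 2, with the step from compound 1 to compound 2 modest and beyond the scatter. A fluoro group at that position is therefore expected to give a number somewhere between those two, and the step from compound 2 to compound 3 is expected to be a 3.4-fold lower number from compound 2 to compound 3 (0.54 log units; beyond the scatter) in this assay. The estimate for compound 3 in this assay is 250000 nM, with a range from 80000 nM to 800000 nM.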

Compound 3, half-maximal cytotoxic concentration: 162000 nM
The estimate for compound 3 lay 1.5-fold (0.19 log units) above the measured number; the range from low to high includes it.
By their numbers in this assay, from the lowest: compounds 1 and 3 (each within the scatter of the next); then compound 2.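

In this assay, replacing methoxy with fluoro at this position gives a 5.3-fold lower number from compound 2 to compound 3 (0.72 log units; beyond the scatter), so the step seen earlier can be reversed by changing the group on this same aromatic carbon, and a small fluoro group does not keep the higher number seen with methoxy. Replacing hydrogen with fluoro gives a 1.5-fold higher number from compound 1 to compound 3 (0.18 log units; within the scatter), which leaves compound 1 and compound 3 indistinguishable in this test, so among these three compounds only methoxy sets its compound apart from the others. The data give no explanation for why methoxy stands apart, as no supporting measurement bears on this result.

On these data alone, what remains open is whether this higher number belongs to methoxy alone or extends to other groups at this position, such as a hydroxy group, an amine or a longer chain like ethoxy. These three compounds also cannot show whether the same replacements would produce steps of similar size on a different aromatic carbon or on another core.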